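A swap of one group on an amide-type nitrogen

The source may hold more compounds than are shown below. What is called first, only, known or untested is meant among the compounds shown, and "the series" means these compounds.

In a functional assay on Jurkat cells (Homo sapiens) for inhibition, read by MTT assay, with a stated time of 72 h (a higher number here means a weaker inhibitor, a lower number a stronger inhibitor), compound 1 (`COc1cccc(/C=C/C(=O)Nc2cc(OC)c(OC)c(OC)c2)c1`) gives 12500 nM as its half-maximal inhibitory concentration. Compound 2 (`C=C(Br)C(=O)Nc1cccc(/C=C/C(=O)Nc2cccc3ccccc23)c1`) gives 680 nM and compound 3 (`C=C(Br)C(=O)Nc1cccc(/C=C/C(=O)Nc2cccc(F)c2)c1`) gives 1000 nM in the same test. Compound 3 thus lies within the scatter of compound 2, while its number is lower than that of compound 1 by well beyond the scatter.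

The next molecule, compound 4 (`C=C(Br)C(=O)Nc1cccc(/C=C/C(=O)Nc2ccc(C)cc2)c1`), has not yet been measured. It carries 4-methylphenyl in place of 3-fluorophenyl on an amide-type nitrogen. Among the compounds with values here, no measured pair of compounds shows this change on its own, so any forecast is tentative. Still, compound 2 (680 nM) and compound 3 (1000 nM) hold different groups at that place, and their values stay within the scatter of each other. On that basis no step beyond the scatter is expected in this assay, and the estimated step is small (no change at the digits printed from compound 3 to compound 4 (within the scatter)). Compound 4 is expected at about 1000 nM, with a likely range from 450 nM to 2300 nM.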

Compound 4, half-maximal inhibitory concentration: 240 nM
The estimate for compound 4 lay 4.2-fold (0.62 log units) above the measured number; measured number outside the range, below it.
By their numbers in this assay, from the lowest: compound 4; then compounds 2 and 3 (each within the scatter of the next); then compound 1.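

In this assay the swap to 4-methylphenyl gives a 4.2-fold lower number from compound 3 to compound 4 (0.62 log units; beyond the scatter) at this place, so the group on this amide-type nitrogen can shift the number beyond the scatter, which the close values of compound 2 and compound 3 alone did not reveal. The group that leaves and the group that enters have the same count of heavy atoms and each has one six-membered aromatic ring of carbon only, so these counts do not separate them. No measurement given here accounts for the difference.

On these data alone, compound 3 and compound 4 differ both in the substituent and in where it sits on the ring, so the share of each in this step stays open. Also open, as far as these compounds go, is how this place would respond to a phenyl ring carrying an amine or a carboxylic acid, or to a longer chain in place of the methyl.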